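From Benzoyl to Phenylsulfonyl on a Shared Core

The compounds below may be only part of what the source reports. "The series", "measured", "known", "first", "only" and "open" are said of these compounds alone.

In a functional assay on HCT-116 cells (Homo sapiens) for cytotoxicity, read by sulforhodamine B assay, with a stated time of 24 h (a higher number here means a weaker inhibitor, a lower number a stronger inhibitor), compound 3 (`O=C1Nc2ccc(S(=O)(=O)N3CCOCC3)cc2/C1=N/NC(=O)c1ccccc1`) gives 28900 nM. That places it within the usual scatter of both relatives: compound 1 (`Cc1ccc(S(=O)(=O)N/N=C2\C(=O)Nc3ccc(S(=O)(=O)N4CCOCC4)cc32)cc1`) gives 23400 nM, and compound 2 (`CC(=O)N/N=C1\C(=O)Nc2ccc(S(=O)(=O)N3CCOCC3)cc21`) gives 29000 nM. Compound 4 (`O=C1Nc2ccc(S(=O)(=O)N3CCOCC3)cc2/C1=N/NS(=O)(=O)c1ccccc1`) has phenylsulfonyl in place of benzoyl on an amine nitrogen.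

The most relevant measured change is a 1.2-fold higher number from compound 1 to compound 3 (0.09 log units; within the scatter), where benzoyl replaces (4-methylphenyl)sulfonyl at the same nitrogen. This is the closest available comparison, although it runs from a sulfonyl group to benzoyl and involves a methyl-bearing ring. The other two changes at this site are a 1.2-fold higher number from compound 1 to compound 2 (0.09 log units; within the scatter) and a 1.0-fold lower number from compound 2 to compound 3 (0.00 log units; within the scatter). All three are small, so no change beyond the scatter is expected in this assay. The estimated step is a 1.2-fold lower number from compound 3 to compound 4 (0.06 log units; within the scatter). Compound 4 is expected to give about 25000 nM, with an estimated range of 15000 nM to 42000 nM.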

Compound 4, half-maximal inhibitory concentration: 13300 nM
Compound 4: the middle estimate sits 1.9-fold (0.27 log units) above what was measured; measured number below the stated range.
By their numbers in this assay, from the lowest: compounds 4, 1, 3 and 2 (each within the scatter of the next, the first and the last beyond it).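

In this assay, within the data shown here, the group on this amine nitrogen makes a difference beyond the scatter for the first time: phenylsulfonyl in place of benzoyl gives a 2.2-fold lower number from compound 3 to compound 4 (0.34 log units; beyond the scatter) and phenylsulfonyl in place of acetyl gives a 2.2-fold lower number from compound 2 to compound 4 (0.34 log units; beyond the scatter) in two modest steps. Hydrogen in place of methyl on the aromatic ring of the sulfonyl group gives a 1.8-fold lower number from compound 1 to compound 4 (0.25 log units; within the scatter) and so does not separate the two sulfonyl compounds, yet compound 1 goes against any simple rule that sulfonyl beats carbonyl here, since it stays within the scatter of compound 2 and compound 3. Nothing measured here explains the shift.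

The compounds shown leave open whether methylsulfonyl on the same nitrogen would behave like phenylsulfonyl. They also leave open what an amine or a carboxylic acid on that phenyl ring would do.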